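Ethoxy for Methoxy(methyl)amino on a Carbonyl Carbon

A few compounds are considered here, and "the series" means these few. Any claim that something is new, unique, unknown or untested is made for them only; others in the source may bear on it.

Compound 1, `CCOC(=O)C[C@H]1[C@@H](O[Si](C)(C)C(C)(C)C)[C@H](n2cnc3c(NC(=O)Nc4ccccc4)ncnc32)O[C@@H]1COC(=O)NC`: 5.21 nM
Compound 2, `CNC(=O)NC[C@H]1O[C@@H](n2cnc3c(NC(=O)Nc4ccccc4)ncnc32)[C@H](O[Si](C)(C)C(C)(C)C)[C@@H]1CC(=O)N(C)OC`: 16.6 nM

Of the compounds shown here, two have been measured in a functional assay on DU-145 cells (Homo sapiens) for antiproliferative activity; a lower number here means a stronger inhibitor of growth, a higher number a weaker inhibitor of growth. Compound 2 stands at the higher of the two numbers, with compound 1 below it by a gap that lies beyond the usual scatter. Compound 1 and compound 2 differ from each other in more than one place. Their two values show only that gap and nothing about any single change.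

Compound 3, `CCOC(=O)C[C@H]1[C@@H](O[Si](C)(C)C(C)(C)C)[C@H](n2cnc3c(NC(=O)Nc4ccccc4)ncnc32)O[C@@H]1CNC(=O)NC`, has not yet been measured. It differs from compound 2 in one place: ethoxy in place of methoxy(methyl)amino on a carbonyl carbon. Going by the values given here, no step between measured compounds isolates this change, so the expectation rests on the two values alone. The step from compound 2 to compound 3 in this assay is expected to be a 1.8-fold lower number from compound 2 to compound 3 (0.27 log units; within the scatter), a modest move toward a lower number. For compound 3 the estimate is 9 nM, with a range from 3 nM to 27 nM.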

Compound 3, concentration for 50% growth inhibition: 4.97 nM
For compound 3 the middle estimate is 1.8-fold (0.26 log units) above the measured one; the measured number falls inside the stated range.
By their numbers in this assay, from the lowest: compounds 3 and 1 (each within the scatter of the next); then compound 2.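

In this assay, going by these compounds alone, the single change of ethoxy in place of methoxy(methyl)amino on a carbonyl carbon now has a size of its own (a 3.3-fold lower number from compound 2 to compound 3 (0.52 log units; beyond the scatter)), so the read-out responds to this group on the carbonyl. The other single change, (methylcarbamoyl)amino in place of (methylcarbamoyl)oxy on a saturated chain carbon bound to a saturated ring carbon, gives a step that the read-out does not separate from scatter (a 1.0-fold lower number from compound 1 to compound 3 (0.02 log units; within the scatter)). Nothing at hand gives a reason for either result.

Going by these compounds, it remains open how a carboxylic acid, or a longer chain such as butoxy, on this carbonyl carbon would read in this assay. Also open, on these data alone, is whether an amine in place of the (methylcarbamoyl)amino group would keep the number of compound 3.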